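Branching the pentyloxy chain: from compound 3 to compound 4

This account rests on a few compounds, and the source may have more. Where it says the series, first, only, none or still open, it means among the compounds named here.

Compound 1 `CCCOc1ccc2oc(/C=C/[S+](C)[O-])cc(=O)c2c1` gives 1100 nM in a functional assay on A549 cells (Homo sapiens) for cytotoxicity, with a stated time of 48 h; a higher number here means a weaker inhibitor, a lower number a stronger inhibitor.
Compound 2 `C[S+]([O-])/C=C/c1cc(=O)c2cc(Cl)ccc2o1` gives 1700 nM in this assay.
Compound 3 `CCCCCOc1ccc2oc(/C=C/[S+](C)[O-])cc(=O)c2c1` gives 1600 nM in this assay.

Among these three numbers compound 3 holds the second highest, yet all three lie within the scatter of one another: a 1.5-fold higher number from compound 1 to compound 3 (0.16 log units; within the scatter) and a 1.1-fold lower number from compound 2 to compound 3 (0.03 log units; within the scatter). Compound 4 `CC(C)CCOc1ccc2oc(/C=C/[S+](C)[O-])cc(=O)c2c1` has the same atoms as compound 3, joined differently: isopropyl in place of propyl on a saturated chain carbon, two bonds along the chain from an oxygen on an aromatic ring. Among the measured compounds shown here, the only measured step that touches this chain is a 1.5-fold higher number from compound 1 to compound 3 (0.16 log units; within the scatter), and it stayed within the scatter; no measured step alters chain branching at all. Compound 4 is therefore expected to sit close to compound 3, with a step of no change at the digits printed from compound 3 to compound 4 (within the scatter) in this assay. In this assay compound 4 is estimated at 1600 nM, in the range 800 nM to 3200 nM.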

Compound 4, half-maximal inhibitory concentration: 1000 nM
Compound 4: middle estimate off by 1.6-fold (0.20 log units), on the high side, and the stated range covers the measured number.
By their numbers in this assay, from the lowest: compounds 4, 1, 3 and 2 (each within the scatter of the next).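

Among the compounds shown here, the first measured change in chain branching stays within the scatter in this assay with a 1.6-fold lower number from compound 3 to compound 4 (0.20 log units; within the scatter) and so gives no sign that isopropyl in place of propyl at this carbon matters here. The comparisons with the shorter chain and the chloro compound also stay within the scatter, with a 1.1-fold lower number from compound 1 to compound 4 (0.04 log units; within the scatter) and a 1.7-fold lower number from compound 2 to compound 4 (0.23 log units; within the scatter) in this same read-out. Nothing available here bears on this result.

Going by these compounds, whether a benzyloxy group, or a chain carrying an amine or a carboxylic acid, would give a step beyond the scatter remains open.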